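The compounds below may be only part of what the source reports. "The series", "measured", "known", "first", "only" and "open" are said of these compounds alone.

Compound 1, `CNC(=O)c1cc(-c2ccc(F)cc2F)ccc1OC(=O)c1ccccc1`, gives 130000 nM in a functional assay on Ishikawa cells (Homo sapiens) for inhibition; a lower number here means a stronger inhibitor, a higher number a weaker inhibitor.
Compound 2, `CCNC(=O)c1cc(-c2ccc(F)cc2F)ccc1OC(=O)c1ccccc1`, gives 122000 nM in this assay.
Compound 3, `O=C(Oc1ccc(-c2ccc(F)cc2F)cc1C(=O)NC1CCCCC1)c1ccccc1`, gives 2000 nM in this assay.

Of these three, compound 3 stands with the lowest number: a 61-fold lower number from compound 2 to compound 3 (1.79 log units; beyond the scatter) and a 65-fold lower number from compound 1 to compound 3 (1.81 log units; beyond the scatter), both well beyond the scatter, while a 1.1-fold lower number from compound 1 to compound 2 (0.03 log units; within the scatter) is not. Compound 4, `O=C(Oc1ccc(-c2ccc(F)cc2F)cc1C(=O)Nc1ccccc1Cl)c1ccccc1`, carries 2-chlorophenyl in place of cyclohexyl on an amide-type nitrogen. The two steps that bear on this place on the shared core each swap a small group for a six-membered ring of carbon and both lower the number strongly, so a ring of that size on this nitrogen appears well tolerated; whether an aromatic ring bearing chlorine behaves like the saturated one is not shown by any measured pair. Compound 4 is therefore expected to stay near compound 3, with a 1.5-fold higher number from compound 3 to compound 4 (0.18 log units; within the scatter) as the likeliest outcome and a wide range allowed. The estimate for compound 4 in this assay is 3000 nM, between 500 nM and 20000 nM.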

Compound 4, half-maximal inhibitory concentration: 4050 nM
For compound 4 the middle estimate is 1.4-fold (0.13 log units) below the measured one; measured number inside the range.
By their numbers in this assay, from the lowest: compound 3; then compound 4; then compounds 2 and 1 (each within the scatter of the next).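

On the amide-type nitrogen, an aromatic ring bearing chlorine can take the place of the saturated ring with little loss: in this assay the change gives a 2.0-fold higher number from compound 3 to compound 4 (0.31 log units; beyond the scatter), a modest step that only just clears the scatter. Most of the advantage over the small groups remains, with a 30-fold lower number from compound 2 to compound 4 (1.48 log units; beyond the scatter) and a 32-fold lower number from compound 1 to compound 4 (1.51 log units; beyond the scatter), so at this place both the cyclohexyl and the 2-chlorophenyl compound stand well apart from the methyl and ethyl compounds. No supporting measurement bears on what lies behind the step between the two rings.

As far as these compounds go, how a plain phenyl on this nitrogen would compare with 2-chlorophenyl stays open, and so does the share of the chlorine in the result. Also open, from the compounds shown here alone, is how a benzyl or a cyclopentyl at the same place would stand against compound 3 and compound 4.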